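The source may report more compounds than this note shows. Statements on the series, on what has been measured and on what is new or still open speak of the compounds shown alone.

Measured compounds in a functional assay on A549 cells (Homo sapiens) for antiproliferative activity, read by MTT assay, with a stated time of 72 h; on this read-out higher numbers stand for weaker inhibition and lower numbers for stronger inhibition:
Compound 1 `COc1cc(-n2cnc3ccc(-c4ccc(Cl)cc4)cc32)cc(OC)c1OC`: a limit of > 10000 nM.
Compound 2 `COc1cc(-n2cnc3ccc(-c4cc(F)ccc4F)cc32)cc(OC)c1OC`: 7940 nM.
Compound 3 `COc1cc(-n2cnc3ccc(-c4ccccc4)cc32)cc(OC)c1OC`: 3060 nM.

Compound 1 stands at the weak end of this assay, giving only a limit, (the limit of > 10000 nM in this assay, at which 1 of the 3 values shown sits), rather than a number. Compound 4 `COc1ccc(-c2ccc3ncn(-c4cc(OC)c(OC)c(OC)c4)c3c2)cc1O` differs from it by 3-hydroxy-4-methoxyphenyl in place of 4-chlorophenyl on an aromatic carbon. Two measured steps leave the same 4-chlorophenyl position: an at least 3.2-fold lower number from compound 1 to compound 3 (0.51 log units; beyond the scatter) and an at least 1.2-fold lower number from compound 1 to compound 2 (0.10 log units; that floor lies within the scatter), the first beyond the scatter and the second within it; among the measured compounds, a 2.6-fold lower number from compound 2 to compound 3 (0.41 log units; beyond the scatter). Both changes at this position moved the number down or left it near the limit, and none moved it up. Compound 4 is therefore expected to show a lower number, an at least 12-fold lower number from compound 1 to compound 4 (1.09 log units; beyond the scatter), with wide uncertainty because compound 1 gives only > 10000 nM. The estimate for compound 4 is 800 nM, between 80 nM and 6000 nM.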

Compound 4, half-maximal inhibitory concentration: 200 nM
Estimate against measurement, compound 4: 4.0-fold (0.60 log units) above, and the stated range covers the measured number.
By their numbers in this assay, from the lowest: compound 4; then compound 3; then compound 2. At a limit, above all of these: compound 1.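

In this assay, chloro and difluoro substitution had gone only with higher numbers than plain phenyl, but compound 4 goes against that, showing that a substituted ring at this position can lower the number: a 15-fold lower number from compound 3 to compound 4 (1.18 log units; beyond the scatter). For the compounds shown here, the change also gives a 40-fold lower number from compound 2 to compound 4 (1.60 log units; beyond the scatter), so it is larger than any step among the earlier compounds. Compound 1 gives only a limit, so its step is a floor, an at least 50-fold lower number from compound 1 to compound 4 (1.69 log units; beyond the scatter): the limit of > 10000 nM in this assay, at which 1 of the 4 values shown sits.

Whether the hydroxy or the methoxy alone accounts for these steps remains open. So does the effect of an amine in place of the hydroxy.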